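A few compounds are considered here, and "the series" means these few. Any claim that something is new, unique, unknown or untested is made for them only; others in the source may bear on it.

The series rests on a single core, seen in compound 1 `COc1cc(/C=C/C(C)=O)ccc1OCc1cn(-c2c(Cl)cccc2Cl)nn1`, whose aromatic nitrogen carries a 2,6-dichlorophenyl group; in a functional assay on HCT-116 cells (Homo sapiens) for antiproliferative activity, read by MTT assay, with a stated time of 48 h (on this read-out lower numbers stand for stronger inhibition and higher numbers for weaker inhibition), compound 1 gives 2000 nM. Compound 2 `COc1cc(/C=C/C(C)=O)ccc1OCc1cn(-c2ccccc2OC)nn1` carries a 2-methoxyphenyl group in that place, and in this assay compound 2 gives 25700 nM. Going by the values given here, the only measured step between neighbouring compounds is a 13-fold higher number from compound 1 to compound 2 (1.11 log units; beyond the scatter). Compound 3 `COc1cc(/C=C/C(C)=O)ccc1OCc1cn(-c2ccc(NC(=O)c3ccccc3)cc2)nn1` carries a benzamido group on the phenyl ring. In this assay compound 3 reaches only the limit of the assay, > 100000 nM, and no number is known for it. Compound 3 thus sits at the limit of > 100000 nM in this assay, at which 1 of the 3 values shown sits, the weakest position the numbers shown can express.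

Compound 4 `COc1cc(/C=C/C(C)=O)ccc1OCc1cn(-c2ccc([N+](=O)[O-])cc2)nn1` differs from compound 3 by nitro in place of benzamido on an aromatic carbon. Among the compounds with values here, no measured step shares this change; the step from compound 1 to compound 2 concerns a different substituent on the aromatic nitrogen, yet it shows that an exchange of the group on that ring can move the read-out by a large amount. A step beyond the scatter in this assay, toward a lower number, is therefore expected, though the starting point is only a limit. Compound 4 is estimated at 40000 nM, in the range 8000 nM to 100000 nM. The expected step is an at least 2.5-fold lower number from compound 3 to compound 4 (0.39 log units; beyond the scatter).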

Compound 4, half-maximal inhibitory concentration: 96300 nM
Compound 4: the middle estimate sits 2.4-fold (0.38 log units) below what was measured; the measured number falls inside the stated range.
By their numbers in this assay, from the lowest: compound 1; then compound 2; then compound 4. At a limit, above all of these: compound 3.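

In this assay, 4-nitrophenyl in place of 2-methoxyphenyl gives a 3.7-fold higher number from compound 2 to compound 4 (0.57 log units; beyond the scatter), and 4-nitrophenyl in place of 2,6-dichlorophenyl gives a 48-fold higher number from compound 1 to compound 4 (1.68 log units; beyond the scatter). Compound 4 therefore provides a measured number for a third group on the aromatic nitrogen, and this number lies higher than those of the two earlier measured compounds, extending the span of numbers seen at this position. Nitro in place of benzamido gives an at least 1.0-fold lower number from compound 3 to compound 4 (0.01 log units; that floor lies within the scatter), and the data do not order nitro and benzamido. The value of compound 3 remains a limit: the limit of > 100000 nM in this assay, at which 1 of the 4 values shown sits.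

The compounds shown leave open how an amine or a carboxylic acid would read in place of nitro on the same ring. They also leave open whether a phenyl ring with a single chlorine would stay close to compound 1 or move toward compound 2 and compound 4.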